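Shrinking the carboxy ring of compound 3

This account rests on a few compounds, and the source may have more. Where it says the series, first, only, none or still open, it means among the compounds named here.

Values in a functional assay on HeLa cells (Homo sapiens) for antiproliferative activity, read by CCK-8 assay, with a stated time of 48 h; on this read-out lower numbers stand for stronger inhibition and higher numbers for weaker inhibition:
- Compound 1 `COc1ccc(/C=C\c2cc(OC)c(OC)c(OC)c2)cc1OCc1ccc(CNC(C)(C)C(=O)O)cc1`: > 10000 nM, a limit of the assay
- Compound 2 `COc1ccc(/C=C\c2cc(OC)c(OC)c(OC)c2)cc1OCc1ccc(C=O)cc1`: 4800 nM
- Compound 3 `COc1ccc(/C=C\c2cc(OC)c(OC)c(OC)c2)cc1OCc1ccc(CN2CC[C@H](C(=O)O)C2)cc1`: > 10000 nM, a limit of the assay

Compound 3 gives no number, because it sits at the limit of > 10000 nM in this assay, at which 2 of the 3 values shown sit. Compound 4 `COc1ccc(/C=C\c2cc(OC)c(OC)c(OC)c2)cc1OCc1ccc(CN2CC(C(=O)O)C2)cc1` keeps the shared core and changes one group: 3-carboxyazetidin-1-yl in place of 3-carboxypyrrolidin-1-yl on a saturated chain carbon bound to an aromatic carbon. In words, 3-carboxyazetidin-1-yl takes the place of 3-carboxypyrrolidin-1-yl on a saturated chain carbon bound to an aromatic carbon.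

Going by the values given here, three measured steps bear on this. Exchanging the formyl group for the pyrrolidine-bearing group gave an at least 2.0-fold higher number from compound 2 to compound 3 (0.31 log units; beyond the scatter). Exchanging the other carboxy-bearing group for formyl gave an at least 2.0-fold lower number from compound 1 to compound 2 (0.31 log units; beyond the scatter). Among the compounds with values here, the only comparison of two carboxy-bearing groups is a step that the two limits leave unreadable from compound 1 to compound 3.

With that comparison as the closest guide, no step beyond the scatter is expected in this assay. The estimated step is a step that the limit leaves unreadable from compound 3 to compound 4. A report of only a limit is the likeliest result. If a number is obtained, the estimate for compound 4 is 12000 nM, with an expected range of 5000 nM to 30000 nM.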

Compound 4, half-maximal inhibitory concentration: 6500 nM
Estimate against measurement, compound 4: 1.8-fold (0.27 log units) above; the range from low to high includes it.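

In this assay, going by these compounds alone, compound 4 is the only one of the three compounds with a carboxy-bearing group on this saturated chain carbon to give a number, so 3-carboxyazetidin-1-yl brings such a compound into the readable range. Replacing formyl gives a 1.4-fold higher number from compound 2 to compound 4 (0.13 log units; within the scatter), so at this place compound 4 and the formyl compound 2 cannot be told apart, which was not shown for either of the other carboxy-bearing groups. The ring change gives an at least 1.5-fold lower number from compound 3 to compound 4 (0.18 log units; that floor lies within the scatter) and the change from the open-chain group gives an at least 1.5-fold lower number from compound 1 to compound 4 (0.18 log units; that floor lies within the scatter), and the true size of both steps stays unknown: the limit of > 10000 nM in this assay, at which 2 of the 4 values shown sit.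

The changed ring size and the loss of the defined stereocentre remain unseparated, and the other stereoisomer of 3-carboxypyrrolidin-1-yl would bear on this. From the compounds shown here alone, whether the carboxylic acid itself matters remains open, and an azetidine ring carrying a methyl ester or a primary amide instead would test it.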